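Swapping Phenyl for Piperazinyl Below the Cytotoxicity Limit

This account rests on a few compounds, and the source may have more. Where it says the series, first, only, none or still open, it means among the compounds named here.

Compound 1 `O=c1nc(-c2ccccc2)c2cc(-c3ccccc3)ccc2[nH]1` was examined in an ADME assay on THP-1 cells (Homo sapiens) for cytotoxicity, read by MTT assay, with a stated time of 72 h; on this read-out higher numbers stand for an effect only at larger amounts of compound and lower numbers for an effect already at smaller amounts. In this assay compound 1 gives > 50000 nM, which is a limit of the assay rather than a number. Compound 2 `O=c1nc(-c2ccccc2)c2ccc(-c3ccncc3)cc2[nH]1` gives > 50000 nM in this assay, also a limit. Compound 3 `O=c1nc(-c2ccccc2)c2ccc(-c3cncnc3)cc2[nH]1` gives > 50000 nM in this assay, again a limit. For the measured compounds named here, the one measured step, a step that the two limits leave unreadable from compound 2 to compound 3, therefore cannot be read, and all three values sit at the limit of > 50000 nM in this assay, at which 3 of the 3 values shown sit. Compound 4 `O=c1nc(-c2ccccc2)c2cc(N3CCNCC3)ccc2[nH]1` differs from compound 1 by piperazin-1-yl in place of phenyl on an aromatic carbon. Going by the values given here, no measured step bears on this change, so no movement beyond the scatter is expected. The step is estimated as a number no higher from compound 1 to compound 4 (the limit leaves the size open). Compound 4 is expected to give 50000 nM, within 20000 nM to 100000 nM, most likely reported as a limit once more.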

Compound 4, half-maximal effective concentration: > 25000 nM
Compound 4: no number, only a limit (the forecaster's own chance of this, stated with the estimate: 80%); the middle value lies beyond the limit too.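

Compound 1 and compound 4 both stand only as limits in this assay, and the step between them cannot be read. The compounds shown leave open the concentration at which any of them would show an effect in this assay.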